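Swapping the Ring Pair on the Chain of Compound 2

A few compounds are considered here, and "the series" means these few. Any claim that something is new, unique, unknown or untested is made for them only; others in the source may bear on it.

Of the compounds shown here, two have so far been measured in an assay on RPMI-8226 cells for antagonist activity at P2X purinoceptor 7 (Homo sapiens), read by calcium flux; a higher number here means a weaker inhibitor, a lower number a stronger inhibitor. Compound 1, `O=c1[nH]c2ccccc2n1CCCN1CCN(S(=O)(=O)c2ccc(F)cc2)CC1`, gives only a limit, > 10000 nM; this is the limit of > 10000 nM in this assay, at which 1 of the 2 values shown sits. Going by the values given here, compound 2, `O=c1[nH]c2ccccc2n1CCCCCN1CCN(C(c2ccccc2)c2ccccc2)CC1`, gives 560 nM, the only actual number in the set, so it stands as the single reference point. Compound 3, `c1ccc(-c2nnnn2CCCCN2CCN(C(c3ccccc3)c3ccccc3)CC2)cc1`, has not yet been measured. It differs from compound 2 in one place: a group of 11 heavy atoms (7 carbon, 4 nitrogen; one five-membered aromatic ring with 4 hetero atoms, one six-membered aromatic ring of carbon only) in place of a group of 11 heavy atoms (8 carbon, 2 nitrogen, 1 oxygen; one five-membered aromatic ring with 2 hetero atoms, one six-membered aromatic ring of carbon only), on a saturated chain carbon, four bonds along the chain from an amine nitrogen in a ring. Among the compounds with values here, no measured pair shows a change of this kind, so any expectation rests on the structural swap alone. A modest weakening is expected, with the step estimated at a 2.7-fold higher number from compound 2 to compound 3 (0.43 log units; beyond the scatter), which may not clearly exceed the usual scatter. Compound 3 is therefore expected to give about 1500 nM in this assay, within a range from 400 nM to 6000 nM.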

Compound 3, half-maximal inhibitory concentration: 3200 nM
Compound 3: middle estimate off by 2.1-fold (0.33 log units), on the low side; measured number inside the range.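

Going by these compounds alone, this is the first step measured at this position in this assay: 5-phenyl-1H-tetrazol-1-yl entering on the chain gives a 5.7-fold higher number from compound 2 to compound 3 (0.76 log units; beyond the scatter). The change weakens the inhibitor without removing its activity, since compound 3 still gives an actual number, 3200 nM, and not a limit. Nothing measured here explains why the number rises.

The whole group changes in a single step, so the compounds shown cannot tell which part of the swap accounts for the rise, including the loss of the group's 1 hydrogen-bond donor. They also leave open how a longer chain carrying 5-phenyl-1H-tetrazol-1-yl, or a carboxylic acid or an amine at this place on the chain, would read in this assay.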